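Notes on the fluoro analogue of compound 3

The source may hold more compounds than are shown below. What is called first, only, known or untested is meant among the compounds shown, and "the series" means these compounds.

Going by the values given here, compound 3 `O=C(CCCCCCc1ccccc1)c1ncc(C(=O)N2CCSCC2)o1` gives 10 nM in an assay (Rattus norvegicus) for inhibition of Fatty-acid amide hydrolase 1 (Homo sapiens) (on this read-out lower numbers stand for stronger inhibition and higher numbers for weaker inhibition), the highest of the three numbers measured so far; compound 1 `Cc1ccnc(-c2cnc(C(=O)CCCCCCc3ccccc3)o2)c1` gives 0.6 nM and compound 2 `NS(=O)(=O)c1ccc(-c2cnc(C(=O)CCCCCCc3ccccc3)o2)s1` gives 3 nM. Against compound 3, the steps run a 17-fold higher number from compound 1 to compound 3 (1.22 log units; beyond the scatter) and a 3.3-fold higher number from compound 2 to compound 3 (0.52 log units; beyond the scatter), and between the two aryl analogues a 5.0-fold higher number from compound 1 to compound 2 (0.70 log units; beyond the scatter).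

Compound 4 `O=C(CCCCCCc1ccccc1)c1ncc(F)o1` differs from compound 3 in one place: fluoro in place of (thiomorpholin-4-yl)carbonyl on an aromatic carbon. The measured steps show that the group at this position moves the number by modest to large amounts, yet none of them tests a single-atom group such as fluoro, and both aryl groups gave lower numbers than the amide. Among the compounds with values here, with no direct precedent, a modest rise beyond the scatter is expected for compound 4, a 3.0-fold higher number from compound 3 to compound 4 (0.48 log units; beyond the scatter), with wide uncertainty. Compound 4 is estimated at 30 nM, with a range from 5 nM to 200 nM.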

Compound 4, inhibition constant: 30 nM
The estimate for compound 4 equals the measured number at the digits printed; low and high end bracket the measured number.
By their numbers in this assay, from the lowest: compound 1; then compound 2; then compound 3; then compound 4.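

In this assay, fluoro on the aromatic carbon next to the ring oxygen gives the highest number of the four compounds, with a 3.0-fold higher number from compound 3 to compound 4 (0.48 log units; beyond the scatter), a 10-fold higher number from compound 2 to compound 4 (1.00 log units; beyond the scatter) and a 50-fold higher number from compound 1 to compound 4 (1.70 log units; beyond the scatter). Going by these compounds alone, the step from the amide is the smallest of these, so exchanging the whole (thiomorpholin-4-yl)carbonyl for a single fluorine loses less than exchanging either aromatic group, and the order runs from the aromatic groups through the amide to fluoro with no compound against it. Nothing on hand accounts for this order.

As far as these compounds go, it remains open whether the rise belongs to fluoro itself or to any small group; a chlorine, a methyl or a nitrile on this carbon would tell. A plain phenyl and an open-chain amide here would show how far the lower numbers depend on the group's ring.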